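A few compounds are considered here, and "the series" means these few. Any claim that something is new, unique, unknown or untested is made for them only; others in the source may bear on it.

Series notes. Compound 3 `O=C1C(O)=C(C(c2cccc([N+](=O)[O-])c2)c2c(-c3ccccc3)[nH]c3ccccc23)C(=O)c2ccccc21` stands second highest of the three numbers in a functional assay on ECa-109 cells (Homo sapiens) for cytotoxicity, read by MTT assay, with a stated time of 48 h (on this read-out higher numbers stand for weaker inhibition and lower numbers for stronger inhibition), giving 5830 nM. Compound 1 `O=C1C(O)=C(C(c2ccccc2)c2c(-c3ccccc3)[nH]c3ccccc23)C(=O)c2ccccc21` gives 5180 nM in this assay, and compound 2 `O=C1C(O)=C(C(c2ccc([N+](=O)[O-])cc2)c2c[nH]c3ccccc23)C(=O)c2ccccc21` gives 60900 nM. Compound 4 `O=C1C(O)=C(C(c2ccc([N+](=O)[O-])cc2)c2c(-c3ccccc3)[nH]c3ccccc23)C(=O)c2ccccc21` differs from compound 3 by 4-nitrophenyl in place of 3-nitrophenyl on a saturated chain carbon bound to an aromatic carbon and a double-bonded ring carbon. Among the measured compounds shown here, compound 2 also carries a 4-nitrophenyl and shows the highest number, but no single counted step joins compound 2 to compound 4, so its value alone does not settle the move. For the measured compounds named here, the only measured change bearing on the nitro group, a 1.1-fold higher number from compound 1 to compound 3 (0.05 log units; within the scatter), stayed within the scatter, so the step of a 1.1-fold higher number from compound 3 to compound 4 (0.05 log units; within the scatter) is expected to be small, in no firm direction. Compound 4 is therefore estimated at 6500 nM, with a range from 2500 nM to 18000 nM.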

Compound 4, half-maximal inhibitory concentration: 5080 nM
Beside the measured number, compound 4's estimate is 1.3-fold (0.11 log units) above it; the range from low to high includes it.
By their numbers in this assay, from the lowest: compounds 4, 1 and 3 (each within the scatter of the next); then compound 2.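

Moving the nitro group from 3-nitrophenyl to 4-nitrophenyl at this saturated chain carbon gives a 1.1-fold lower number from compound 3 to compound 4 (0.06 log units; within the scatter) in this assay and so leaves the number unchanged within the scatter. The 4-nitrophenyl also stays level with the plain phenyl, with a 1.0-fold lower number from compound 1 to compound 4 (0.01 log units; within the scatter) within the scatter. Among the compounds shown here, the phenyl change elsewhere on the core, a 12-fold lower number from compound 2 to compound 4 (1.08 log units; beyond the scatter) beyond the scatter, is the one large step here, and this comparison now confirms it at a single nitro placement.

No evidence on the cause of these steps is at hand. From the compounds shown here alone, whether an amine or a carboxylic acid on this phenyl would shift the number remains open, as does the effect of a methyl in place of the added phenyl.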